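The compounds below may be only part of what the source reports. "The series", "measured", "known", "first", "only" and "open" are said of these compounds alone.

Of the compounds shown here, two that share one core have been measured so far. Compound 1 `CCN1CCc2c(c(C)nn2C(=O)Nc2cc(C)ccc2F)C1` and compound 2 `CCN1CCc2c(c(C)nn2C(=O)Nc2ccc(Cl)cc2)C1` were each given at a single dose in a functional assay on the whole organism (strain Swiss albino) for inhibition, with Mus musculus as the target, in the formalin test, with stated times of 30 min and 5 min, at a dose of 100 mg/kg; on this read-out lower numbers stand for less inhibition and higher numbers for more inhibition at the one dose given (going by the name of the read-out). In this assay compound 1 gives 5.2%, and compound 2 gives 1.7%. Compound 2 stands alongside compound 1: the two numbers lie within the usual scatter of each other, so no order can be read between them, and both point to little inhibition at the dose used.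

Compound 3 `CCN1CCc2c(c(C(C)(C)C)nn2C(=O)Nc2ccc(Cl)cc2)C1` has not been measured. It differs from compound 2 in one place: tert-butyl in place of methyl on an aromatic carbon. The group in question sits on an aromatic carbon of a five-membered aromatic ring with 2 nitrogen, part of a fused or bridged system of two rings, next to the ring nitrogen.

Going by the values given here, no step between measured compounds is available to show what such a change does in this assay. With compound 2 at 1.7% and compound 1 at 5.2%, both showing little inhibition, the expected step of a number 2.3 percentage points higher from compound 2 to compound 3 (within the scatter) is small and not beyond the scatter in either direction. Compound 3 is therefore expected to give 4%, with a range from 0% to 15%.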

Compound 3, a percentage reported as inhibition, in the whole organism at one dose (the size of the read-out at that dose, not a potency): 3.5%
Estimate against measurement, compound 3: 0.5 percentage points above; low and high end bracket the measured number.
By their numbers in this assay, from the lowest: compounds 2, 3 and 1 (each within the scatter of the next).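

Swapping methyl for tert-butyl, a group of 4 carbon atoms in place of a group of 1, on this aromatic carbon of the five-membered ring gives in this assay a number 1.8 percentage points higher from compound 2 to compound 3 (within the scatter). Going by these compounds alone, this is the first direct view of a change at this position, and the step cannot be told apart from the scatter, so the larger count of carbon atoms leaves no readable mark on the result. Within the data shown here, all the numbers so far are small and come from a single dose, so this step says little about how the position would behave in a compound with clear inhibition, and nothing on hand offers an explanation for the result.

Among these compounds, what an amine, a carboxylic acid or a longer chain such as n-butyl would do on this same aromatic carbon remains open, as does whether tert-butyl gives a similar result when paired with the substituted aromatic ring of compound 1 in place of the one in compound 2. Also open, as far as these compounds go, is whether any group at this position can lift the read-out clearly beyond the scatter.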